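A few compounds are considered here, and "the series" means these few. Any claim that something is new, unique, unknown or untested is made for them only; others in the source may bear on it.

Compound 1 `CCN1C(=O)c2c(nc(C(N)=O)n2Cc2ccc(OC)c(Br)c2)N2C1=N[C@@H]1CCC[C@@H]12` and compound 2 `CCN1C(=O)c2c(nc(C(N)=O)n2Cc2ccc(O)c(Br)c2)N2C1=N[C@@H]1CCC[C@@H]12` differ only at one place. In a physicochemical assay for lipophilicity, measured as octanol-water partition (a higher number here means a more lipophilic compound, a lower number a more polar compound), compound 1 gives 3.3, while compound 2 gives 3.03. The change between them, (hydrogen in place of methyl on an oxygen on an aromatic ring), made a number 0.27 log units lower from compound 1 to compound 2 (within the scatter). Compound 3 `CCN1C(=O)c2c(nc(C(=O)NC)n2Cc2ccc(OC)c(Cl)c2)N2C1=N[C@@H]1CCC[C@@H]12` carries a core that differs from the core of compound 1, and that difference between the two cores is not broken down here; in this assay compound 3 gives 3.26. Compound 4 `CCN1C(=O)c2c(nc(C(=O)NC)n2Cc2ccc(O)c(Cl)c2)N2C1=N[C@@H]1CCC[C@@H]12` is related to compound 3 by the same change, (hydrogen in place of methyl on an oxygen on an aromatic ring), at a place described in the same words as in the earlier pair. Because the earlier pair showed a number 0.27 log units lower from compound 1 to compound 2 (within the scatter), the step from compound 3 to compound 4 is expected to be of similar size, about a number 0.26 log units lower from compound 3 to compound 4 (within the scatter). Compound 4 is therefore estimated at 3, expected to lie between 2.7 and 3.3.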

Compound 4, partition coefficient: 3
For compound 4 middle estimate and measured number coincide at the digits printed; the measured number falls inside the stated range.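

In this assay, the change from methoxy to hydroxy on the second core gave a number 0.26 log units lower from compound 3 to compound 4 (within the scatter), close in size to a number 0.27 log units lower from compound 1 to compound 2 (within the scatter), so on these two cores the step carried over with little difference. Each step lies within the scatter, so neither pair shows on its own that the change moves the number at all, and two pairs make no rule for the whole series. Nothing measured here explains why the two steps match.

As far as these compounds go, whether the match would hold on further cores stays open. So does the outcome of placing an amine or a carboxylic acid on the ring instead of hydroxy, or of an ethyl group or longer chain on the oxygen instead of methyl.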